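A few compounds are considered here, and "the series" means these few. Any claim that something is new, unique, unknown or untested is made for them only; others in the source may bear on it.

The measured compounds are these. Compound 1 `Cc1c(O)nc(S(=O)(=O)Cc2ccc(Br)cc2)nc1Cc1c(Cl)cccc1Cl` is the starting point; in a functional assay on MT4 cells (Homo sapiens) for cytotoxicity, read by MTT assay (a lower number here means that less compound is tolerated, a higher number that more compound is tolerated), compound 1 gives > 50000 nM, which is a limit of the assay and not a number. Compound 2 `Cc1c(O)nc(SCc2ccc([N+](=O)[O-])cc2)nc1Cc1c(Cl)cccc1Cl` gives > 58000 nM, also a limit. Compound 3 `COc1cc(CSc2nc(O)c(C)c(Cc3c(F)cccc3F)n2)cc(OC)c1` gives > 60000 nM, again a limit.

Compound 1 therefore stands on no number at all in this assay: its result is the limit (the limit of > 50000 nM in this assay, at which 1 of the 3 values shown sits). Among the compounds with values here, the other two values are likewise limits, the limit of > 58000 nM in this assay, at which 1 of the 3 values shown sits, and (the limit of > 60000 nM in this assay, at which 1 of the 3 values shown sits), so among the three compounds there is no measured step and no ordering, only that each is tolerated up to the highest concentration tested.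

The unmeasured compound 4 `COc1ccc(CS(=O)(=O)c2nc(O)c(C)c(Cc3c(Cl)cccc3Cl)n2)cc1` differs from compound 1 in one place: methoxy in place of bromo on an aromatic carbon. Within the data shown here, there is no measured pair sharing this change against which its effect could be read. With every shown value sitting at a limit, no step beyond the scatter is expected in this assay from the change in compound 4; the expected step that the limit leaves unreadable from compound 1 to compound 4 is none beyond the scatter.

Compound 4 is estimated to give about 60000 nM, within 30000 nM to 200000 nM, and most likely again only as a limit.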

Compound 4, half-maximal cytotoxic concentration: 2800 nM
Compound 4: middle estimate off by 21-fold (1.33 log units), on the high side, outside the stated range (below it).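

In this assay, methoxy in place of bromo on an aromatic carbon, para to a large group, gives an at least 17-fold lower number from compound 1 to compound 4 (1.25 log units; beyond the scatter). Within the data shown here, compound 4, at 2800 nM, is the first compound here with a real number rather than a limit, so this one exchange, 4-bromophenyl to 4-methoxyphenyl, is enough to bring the toxicity of the shared core into the range the assay can read, and this position is therefore not indifferent to what sits on it. The size of the step can be stated only as a minimum because the value of compound 1 is a limit and not a number: the limit of > 50000 nM in this assay, at which 1 of the 4 values shown sits.

The compounds shown do not tell whether the change belongs to the arrival of the methoxy group or to the loss of the bromo group, and a plain hydrogen, a hydroxyl, an amine or an ethoxy group at this place would separate the two. They also leave open whether the same exchange would act alike with the thioether link of compound 2 and compound 3, since each of those differs from compound 1 in more than one place.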